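Piperidine to pyrrolidine on the propyl side chain

The compounds below may be only part of what the source reports. "The series", "measured", "known", "first", "only" and "open" are said of these compounds alone.

In a functional assay on PC-3 cells (Homo sapiens) for antiproliferative activity, read by MTT assay, with a stated time of 72 h (a lower number here means a stronger inhibitor, a higher number a weaker inhibitor), compound 3 (`O=C(N/N=C/c1cccn1CCCN1CCCCC1)Nc1ccc(Oc2ccnc3[nH]ccc23)cc1`) gives 3580 nM. Compound 2 (`O=C(N/N=C/c1cccn1CCCN1CCCC1)Nc1ccc(Oc2ccnc3[nH]ccc23)c(F)c1`) gives 3580 nM, so the two stand level, together the highest of the three numbers. Compound 1 (`CCN(CC)CCn1cccc1/C=N/NC(=O)Nc1ccc(Oc2ccnc3[nH]ccc23)cc1`) has the lowest number at 1370 nM.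

The next structure is compound 4 (`O=C(N/N=C/c1cccn1CCCN1CCCC1)Nc1ccc(Oc2ccnc3[nH]ccc23)cc1`), and the change is pyrrolidin-1-yl in place of piperidin-1-yl on a saturated chain carbon, three bonds along the chain from an aromatic nitrogen. For the measured compounds named here, no measured step isolates this exchange. The nearest evidence is a 2.6-fold higher number from compound 1 to compound 3 (0.42 log units; beyond the scatter), a modest step for (piperidin-1-yl)methyl in place of diethylamino. That is a different change at a different place, so it gives only a rough sense of how far the number moves when this part of the structure is altered.

Compound 2 carries 3-(pyrrolidin-1-yl)propyl on a core of its own, and its value of 3580 nM gives no sign of a number far from that of compound 3. A five-membered ring in place of a six-membered one is also a smaller exchange than the measured one. No step beyond the scatter is therefore expected in this assay, and no direction can be called. The estimated step is a 1.2-fold lower number from compound 3 to compound 4 (0.08 log units; within the scatter). For compound 4 the expected value is 3000 nM, with an estimated range of 1300 nM to 7000 nM.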

Compound 4, half-maximal inhibitory concentration: 4290 nM
Compound 4: middle estimate off by 1.4-fold (0.16 log units), on the low side, within the range that was stated.
By their numbers in this assay, from the lowest: compound 1; then compounds 2, 3 and 4 (each within the scatter of the next).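

Notes on the amine ring: in this assay the exchange of 3-(piperidin-1-yl)propyl for 3-(pyrrolidin-1-yl)propyl now has a measured step of its own (a 1.2-fold higher number from compound 3 to compound 4 (0.08 log units; within the scatter)), so at this place, three bonds along the chain from an aromatic nitrogen, the change from the six-membered to the five-membered ring gives no separation beyond the scatter. The fluoro group on the aromatic carbon can now also be read alone, and hydrogen in its place likewise stays within the scatter (a 1.2-fold higher number from compound 2 to compound 4 (0.08 log units; within the scatter)). The gap to the diethylamino side chain of compound 1 holds for the pyrrolidine as it does for the piperidine (a 3.1-fold higher number from compound 1 to compound 4 (0.50 log units; beyond the scatter); a 2.6-fold higher number from compound 1 to compound 3 (0.42 log units; beyond the scatter)), and both steps lie beyond the scatter, so the two rings stand on the same side of compound 1.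

In those two steps the amine and the chain length change together, so a 3-(diethylamino)propyl or a 2-(pyrrolidin-1-yl)ethyl side chain would be needed to separate them, and a morpholin-4-yl ring on the propyl chain remains an open case. Nothing available bears on why these numbers fall as they do.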